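The source may hold more compounds than are shown below. What is called first, only, known or untested is meant among the compounds shown, and "the series" means these compounds.

In an ADME assay on DU-145 cells (Homo sapiens) for cytotoxicity, read by MTT assay, with a stated time of 72 h (on this read-out lower numbers stand for stronger inhibition and higher numbers for weaker inhibition), compound 1 (`COc1ccc(C2=C(c3cc(OC)c(OC)c(OC)c3)C(=O)CC2O[SiH2]C(C)(C)C)cc1`) gives > 100 ug/mL, which is a limit of the assay and not a number. Compound 2 (`COc1cc(C2=C(c3ccccc3)C(O[SiH2]C(C)(C)C)CC2=O)cc(OC)c1OC`) gives > 100 ug/mL, also a limit. For the measured compounds named here, compound 1 therefore has no numerical position, and the only other value shown offers no reference point: the limit of > 100 ug/mL in this assay, at which 2 of the 2 values shown sit. Going by the values given here, the one measured step, a step that the two limits leave unreadable from compound 1 to compound 2, supplies no size to carry forward, and it concerns a hydrogen in place of methoxy on an aromatic carbon.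

Compound 3 (`COc1ccc(C2=C(c3cc(OC)c(OC)c(OC)c3)C(=O)CC2O)cc1`) differs from compound 1 by a hydrogen atom in place of a group of 5 heavy atoms (4 carbon, 1 silicon; no ring), on an oxygen on a saturated carbon: a hydrogen atom replaces a group of 5 heavy atoms, on an oxygen on a saturated carbon. This change has not been measured in the series, so the expectation is loose. Any readable value would lie toward stronger inhibition, and a second limit remains possible. The expected change is an at least 6.6-fold lower number from compound 1 to compound 3 (0.82 log units; beyond the scatter). For compound 3, the estimated value is 15 ug/mL, with an expected range of 1 ug/mL to 100 ug/mL.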

Compound 3, half-maximal inhibitory concentration: 18.7 ug/mL
Beside the measured number, compound 3's estimate is 1.2-fold (0.10 log units) below it; measured number inside the range.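

In this assay, for the compounds shown here, the oxygen on a saturated carbon gives the first readable step: a hydrogen atom in place of the group of 5 heavy atoms (4 carbon, 1 silicon; no ring) gives an at least 5.3-fold lower number from compound 1 to compound 3 (0.72 log units; beyond the scatter). That size is a floor only, as the value of compound 1 is a limit and not a number. Among the compounds shown, a numerical value appears only with the hydrogen on this oxygen, and the remaining values give no scale for comparison: the limit of > 100 ug/mL in this assay, at which 2 of the 3 values shown sit.

Only two states of this oxygen are shown, so a smaller group such as methyl or acetyl there would be needed to tell whether any group at this place gives a limit. The step from compound 1 to compound 2 cannot be read, which leaves open what hydrogen in place of methoxy on an aromatic carbon does in this series.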